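The compounds below may be only part of what the source reports. "The series", "measured", "known", "first", "only" and "open" are said of these compounds alone.

Measured so far:
compound 1 `Cn1nc(-c2cccnc2)c2ccccc2c1=O` — 63%
compound 2 `O=c1c2ccccc2c(-c2cccnc2)nn1C1CCCC1` — 97%
compound 3 `O=C(c1cccs1)n1nc(-c2cccnc2)c2ccccc2c1=O` — 37%

In an assay on isolated protein (Oryctolagus cuniculus) with Thromboxane-A synthase (Homo sapiens) as the target, tested at 1 uM (on this read-out higher numbers stand for more inhibition at the one concentration tested (going by the name of the read-out) and lower numbers for less inhibition), compound 3 stands lowest of the three numbers: the steps are a number 26 percentage points lower from compound 1 to compound 3 (beyond the scatter) and a number 60 percentage points lower from compound 2 to compound 3 (beyond the scatter), both beyond the scatter. Compound 4 `O=C(O)Cn1nc(-c2cccnc2)c2ccccc2c1=O` differs from compound 3 by carboxymethyl in place of (thiophen-2-yl)carbonyl on an aromatic nitrogen. Both steps into compound 3 bear on this change, since they show the (thiophen-2-yl)carbonyl substituent on that nitrogen giving the lowest number, while methyl in compound 1 and cyclopentyl in compound 2 give higher numbers. Carboxymethyl is, like those two, not an acyl group, so compound 4 is expected to recover part of that loss, a step of about a number 31 percentage points higher from compound 3 to compound 4 (beyond the scatter) in this assay. Estimated for compound 4: 68%, range 45% to 90%.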

Compound 4, a percentage reported as inhibition, at one concentration (the size of the read-out at that concentration, not a potency): 13%
For compound 4 the middle estimate is 55 percentage points above the measured one, and the stated range ends above it.
By their numbers in this assay, from the lowest: compound 4; then compound 3; then compound 1; then compound 2.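

In this assay, the absence of an acyl group does not by itself keep the number up at this aromatic nitrogen: carboxymethyl in place of (thiophen-2-yl)carbonyl gives a number 24 percentage points lower from compound 3 to compound 4 (beyond the scatter) and the lowest number of the series. Carboxy on the saturated chain carbon gives a number 50 percentage points lower from compound 1 to compound 4 (beyond the scatter) and, set against cyclopentyl, carboxymethyl gives a number 84 percentage points lower from compound 2 to compound 4 (beyond the scatter) in the same series. No measurement at hand accounts for these drops.

Still open, from the compounds shown here alone, is whether an ester or primary amide in place of the carboxylic acid would stay as low as compound 4. Going by these compounds, a longer chain ending in a carboxylic acid is equally open.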